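This account rests on a few compounds, and the source may have more. Where it says the series, first, only, none or still open, it means among the compounds named here.

Measured compounds:
compound 1, `CC(=O)N1N=C(c2cc(Cl)ccc2N)SC1(C)C`, giving 72.8%
compound 2, `CCC(=O)N1N=C(c2cc(Cl)ccc2N)SC1(C)C`, giving 1.07%
compound 3, `CCCC(=O)N1N=C(c2ccccc2N)SC1(C)C`, giving 35.2%

All three were tested in an assay on isolated protein for inhibition of Nitric oxide synthase, inducible (Homo sapiens), read by scintillation counting, with a stated time of 30 min, tested at 50 uM; a higher number here means more inhibition at the concentration tested (going by the name of the read-out), a lower number less inhibition. Compound 1 and compound 2 share one core, and the change between them is methyl in place of hydrogen on a saturated chain carbon bound to a carbonyl carbon. That change produced a number 71.7 percentage points lower from compound 1 to compound 2 (beyond the scatter), a drop well beyond the scatter. Compound 3 stands on a different core, and the difference between the two cores is not broken down here. In this assay compound 3 sits between the other two: its step to compound 2 and its step to compound 1 are both beyond the scatter.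

Compound 4, `CCCCC(=O)N1N=C(c2ccccc2N)SC1(C)C`, has not yet been measured. It is made from compound 3 by methyl in place of hydrogen on a saturated chain carbon, three bonds along the chain from a carbonyl carbon. This is the same kind of change as that from compound 1 to compound 2, but not the same: there the methyl entered on a saturated chain carbon bound to a carbonyl carbon, here it enters on a saturated chain carbon, three bonds along the chain from a carbonyl carbon.

Within the data shown here, because the only measured step of this kind, a number 71.7 percentage points lower from compound 1 to compound 2 (beyond the scatter), was a large loss, a loss is also expected from compound 3 to compound 4, but a smaller one is estimated, a number 15.2 percentage points lower from compound 3 to compound 4 (beyond the scatter), since the place of the change differs and the core differs. Compound 4 is therefore expected to give about 20% in this assay, estimated between 0% and 55%.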

Compound 4, a percentage reported as inhibition, at one concentration (the size of the read-out at that concentration, not a potency): 39.1%
Compound 4: the middle estimate sits 19.1 percentage points below what was measured; the range from low to high includes it.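

In this assay, methyl in place of hydrogen on a saturated chain carbon, three bonds along the chain from a carbonyl carbon, gave a number 3.9 percentage points higher from compound 3 to compound 4 (within the scatter), and this step differs clearly from the earlier one: the same change on two cores in this assay, a number 71.7 percentage points lower (beyond the scatter) from compound 1 to compound 2 and a number 3.9 percentage points higher (within the scatter) from compound 3 to compound 4, 75.6 percentage points apart, beyond the scatter of two such steps The large loss seen on the core of compound 1 therefore does not carry over as a fixed amount to the core of compound 3, and a step of this kind read on one core gave no reliable size for the other in this series. It does not show whether the core or the place of the methyl accounts for the gap, as the two steps differ in both, and one pair on each core says nothing about a general rule or about the reason for the gap.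

The compounds shown leave open how a longer chain than that of compound 4, a branched chain such as isopropyl, or a phenyl group at the same carbonyl would read in this assay. Also open is what the chlorine of compound 1 and compound 2 contributes, as no pair shown differs in that place alone.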